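Trifluoromethylphenyl Replaces Methoxyphenyl on the Shared Core

A few compounds are considered here, and "the series" means these few. Any claim that something is new, unique, unknown or untested is made for them only; others in the source may bear on it.

Compound 2 `COc1ccc(-c2cn3ccnc3c(-c3ccc4ncn(C5CCCCC5)c4c3)n2)cc1` gives 61% in a functional assay on ACHN cells (Homo sapiens) for inhibition, read by sulforhodamine B assay, with a stated time of 48 h, tested at 10 uM (on this read-out lower numbers stand for less inhibition and higher numbers for more inhibition at the one concentration tested (going by the name of the read-out)), the highest of the three values recorded. Compound 1 `Brc1cn2ccnc2c(-c2ccc3ncn(C4CCCCC4)c3c2)n1` gives 11.5%, and compound 3 `CC(=O)c1ccc(-c2cn3ccnc3c(-c3ccc4ncn(C5CCCCC5)c4c3)n2)cc1` gives 4.32%. Compound 4 `FC(F)(F)c1cccc(-c2cn3ccnc3c(-c3ccc4ncn(C5CCCCC5)c4c3)n2)c1` differs from compound 2 by 3-(trifluoromethyl)phenyl in place of 4-methoxyphenyl on an aromatic carbon. Going by the values given here, two steps bear on this change: the step of a number 49.5 percentage points higher from compound 1 to compound 2 (beyond the scatter) shows the gain that 4-methoxyphenyl brings over bromo, and the step of a number 56.7 percentage points lower from compound 2 to compound 3 (beyond the scatter) shows that acetyl in place of methoxy removes it, while a number 7.2 percentage points lower from compound 1 to compound 3 (within the scatter). Compound 1 and compound 3, the two without methoxy, both sit low, so the trifluoromethyl variant is expected to fall as well, giving a number 36 percentage points lower from compound 2 to compound 4 (beyond the scatter). Compound 4 is therefore estimated at 25%, within 5% to 55%.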

Compound 4, a percentage reported as inhibition, at one concentration (the size of the read-out at that concentration, not a potency): 0.3%
Compound 4: the middle estimate sits 24.7 percentage points above what was measured; measured number below the stated range.
By their numbers in this assay, from the lowest: compounds 4, 3 and 1 (each within the scatter of the next, the first and the last beyond it); then compound 2.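

In this assay, an aryl group at this aromatic carbon does not by itself keep the read-out high, since 3-(trifluoromethyl)phenyl gives a number 60.7 percentage points lower from compound 2 to compound 4 (beyond the scatter). The new group stays level with 4-acetylphenyl, at a number 4 percentage points lower from compound 3 to compound 4 (within the scatter), and even falls short of bromo, at a number 11.2 percentage points lower from compound 1 to compound 4 (beyond the scatter), so of the four compounds only compound 2 stands high. Nothing given here explains this drop. The change swaps the substituent and moves it on the phenyl ring together, so 3-methoxyphenyl and 4-(trifluoromethyl)phenyl would be needed to separate the two. Going by these compounds, whether 4-ethoxyphenyl or 4-aminophenyl would hold the level of compound 2 also remains open.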